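Fluorine on the cinnamyl ring: a halogen step weighed

This account rests on a few compounds, and the source may have more. Where it says the series, first, only, none or still open, it means among the compounds named here.

Compound 1 `COC(OC)C1=C(C(=O)OC/C=C/c2ccccc2)C(c2cccc(Cl)c2)C(C(=O)O)=C(C)N1` shows the highest number of the three measured compounds in an assay on thoracic aorta for inhibition of Voltage-gated L-type calcium channel (Rattus norvegicus) (on this read-out higher numbers stand for weaker inhibition and lower numbers for stronger inhibition), giving 8100 nM. Compound 2 `CC1=C(C(=O)O)C(c2cccc(Cl)c2)C(C(=O)OC/C=C/c2ccccc2)=C(C#N)N1` gives 2000 nM in this assay, and compound 3 `COC(OC)C1=C(C(=O)OC/C=C/c2ccccc2Cl)C(c2cccc(Cl)c2)C(C(=O)O)=C(C)N1` gives 700 nM. The step of a 4.1-fold lower number from compound 1 to compound 2 (0.61 log units; beyond the scatter) is modest, while the step of a 12-fold lower number from compound 1 to compound 3 (1.06 log units; beyond the scatter) is large.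

Compound 4 `COC(OC)C1=C(C(=O)OC/C=C/c2ccc(F)cc2)C(c2cccc(Cl)c2)C(C(=O)O)=C(C)N1` differs from compound 1 in one place: fluoro in place of hydrogen on an aromatic carbon. The carbon that takes the fluorine is para to a large group on the ring. Among the measured compounds shown here, of the two measured steps, only that from compound 1 to compound 3 bears on this change, since it also places a halogen on the same aromatic ring, though a chloro rather than a fluoro and on another carbon of that ring. The step from compound 1 to compound 2 alters a different part of the shared core and gives no guidance here.

On this basis compound 4 is expected to show a lower number than compound 1 in this assay, a step beyond the scatter but smaller than that to compound 3, estimated as a 2.3-fold lower number from compound 1 to compound 4 (0.36 log units; beyond the scatter). Compound 4 is therefore estimated at 3500 nM, within a range from 1200 nM to 9000 nM.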

Compound 4, half-maximal inhibitory concentration: 2000 nM
Estimate against measurement, compound 4: 1.8-fold (0.24 log units) above; low and high end bracket the measured number.
By their numbers in this assay, from the lowest: compound 3; then compounds 2 and 4 (each within the scatter of the next); then compound 1.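

The cinnamyl ring of compound 1 now has a second measured halogen change in this assay: a single fluoro on the aromatic carbon para to a large group gives a 4.1-fold lower number from compound 1 to compound 4 (0.61 log units; beyond the scatter), so a step beyond the scatter on this ring is not confined to the chloro of compound 3. The two halogen-bearing rings also differ from each other, with a 2.9-fold higher number from compound 3 to compound 4 (0.46 log units; beyond the scatter), which sets the 4-fluorophenyl compound apart from the 2-chlorophenyl compound by more than the usual scatter of this measurement. That step changes both the halogen and the ring carbon that carries it, and nothing given here accounts for either step.

Going by these compounds, whether the gap between compound 3 and compound 4 follows the change of halogen or the change of carbon remains open. Also open, on these data alone, are what a methoxy group or an amine would do on the carbon that carries the fluorine, and whether the fluoro step would hold alongside the nitrile of compound 2.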